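From a Nitrile Arm to a Pyrrole Arm

The source may hold more compounds than are shown below. What is called first, only, known or untested is meant among the compounds shown, and "the series" means these compounds.

Compound 1, `N#Cc1ccc(/C=N/NC(=O)Nc2ccc(Oc3ccnc4[nH]ccc34)c(F)c2)cc1`, was examined in a functional assay on HepG2 cells (Homo sapiens) for antiproliferative activity, read by MTT assay, with a stated time of 72 h; a lower number here means a stronger inhibitor, a higher number a weaker inhibitor. In this assay, among the compounds with values here, compound 1 gives 850 nM, and it is the only compound of the set to come with a number at all. Compound 2, `COc1cc(/C=N/NC(=O)Nc2ccc(Oc3ccnc4[nH]ccc34)c(F)c2)cc(OC)c1OC`, is recorded in this assay as "not active" (no number reported), a statement without a value. Compound 3, `O=C(N/N=C/c1ccc(O)cc1Br)Nc1ccc(Oc2ccnc3[nH]ccc23)cc1`, is recorded in this assay as "not determined" (no result reported), so no result exists for it. Within the data shown here, compound 1 therefore stands alone as the single measured anchor; nothing here can rank it against the other two, and no step between two measured compounds is available.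

Compound 4, `CN(C)CCn1cccc1/C=N/NC(=O)Nc1ccc(Oc2ccnc3[nH]ccc23)c(F)c1`, is the compound still to be tested. Set against compound 1 the change is 1-(2-(dimethylamino)ethyl)-1H-pyrrol-2-yl in place of 4-cyanophenyl on a carbon with a double bond to nitrogen. The ring that enters is a five-membered aromatic ring with one hetero atom, carrying the 2-(dimethylamino)ethyl chain, in place of the 4-cyanophenyl group on the carbon with a double bond to nitrogen.

Among the measured compounds shown here, with no measured step to lean on, the expected step is small: compound 4 is expected to land near compound 1 or somewhat weaker, so the step expected a 1.8-fold higher number from compound 1 to compound 4 (0.25 log units; within the scatter) lies at the edge of the usual scatter. Compound 4 is estimated at 1500 nM, with a range from 300 nM to 8000 nM.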

Compound 4, half-maximal inhibitory concentration: 8980 nM
Estimate against measurement, compound 4: 6.0-fold (0.78 log units) below; the whole stated range lies below it.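

In this assay, within the data shown here, putting 1-(2-(dimethylamino)ethyl)-1H-pyrrol-2-yl in place of 4-cyanophenyl on the carbon with a double bond to nitrogen gives an 11-fold higher number from compound 1 to compound 4 (1.02 log units; beyond the scatter) as the first measured step of this set. It shows that the group on this carbon matters: with the rest of the molecule unchanged, this one exchange moves the reading by far more than repeated measurements would. Compound 4 still has a numerical result, so this change weakens the antiproliferative reading without leaving it as a bare statement of no activity, but nothing shown explains the loss.

The exchange alters two things at once, the ring and the chain it carries, so the compounds shown cannot tell which of them accounts for the step. A plain 1H-pyrrol-2-yl group with only a hydrogen on the ring nitrogen would test the ring alone, while a phenyl ring bearing the same 2-(dimethylamino)ethyl chain would test the chain alone.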